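Methyl in place of the ester-bearing chain on ring nitrogen

The source may hold more compounds than are shown below. What is called first, only, known or untested is meant among the compounds shown, and "the series" means these compounds.

Compound 1 `COC(=O)Cn1nc2c(n1)C(=O)C(C)=C(C)C2=O` gives 4 ug/mL in a functional assay on KB cells (Homo sapiens) for inhibition, read by colorimetric assay, with a stated time of 72 h; on this read-out lower numbers stand for an effect already at smaller amounts and higher numbers for an effect only at larger amounts of compound. Compound 2 `COC(=O)C(C)n1nc2c(n1)C(=O)C(C)=C(C)C2=O` gives 3.5 ug/mL in this assay, the step of a 1.1-fold lower number from compound 1 to compound 2 (0.06 log units; within the scatter) being within the scatter; compound 2 thus holds the lower of the two numbers, with compound 1 within the scatter of it. Compound 3 `CC1=C(C)C(=O)c2nn(C)nc2C1=O` differs from compound 2 by methyl in place of 1-(methoxycarbonyl)ethyl on an aromatic nitrogen. For the measured compounds named here, only a 1.1-fold lower number from compound 1 to compound 2 (0.06 log units; within the scatter) touches this position, and it merely altered the chain, not removed it; no measured step covers loss of the methoxycarbonyl group. A step of a 1.4-fold higher number from compound 2 to compound 3 (0.15 log units; within the scatter) is therefore expected, near the scatter. Compound 3 is estimated at 5 ug/mL, between 2 ug/mL and 12 ug/mL.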

Compound 3, concentration for half-maximal effect: 3 ug/mL
Compound 3: middle estimate off by 1.7-fold (0.22 log units), on the high side; low and high end bracket the measured number.
By their numbers in this assay, from the lowest: compounds 3, 2 and 1 (each within the scatter of the next).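

Methyl in place of 1-(methoxycarbonyl)ethyl on the aromatic nitrogen gives a 1.2-fold lower number from compound 2 to compound 3 (0.07 log units; within the scatter) in this assay, and hydrogen in place of methoxycarbonyl on the saturated chain carbon gives a 1.3-fold lower number from compound 1 to compound 3 (0.12 log units; within the scatter). Across compounds 1, 2 and 3, the read-out therefore does not depend on the ester-bearing chain: removing the methoxycarbonyl group leaves the numbers within the scatter. No supporting data bear on why this position tolerates the change. Going by these compounds, whether a carboxylic acid, an amine or a longer chain on this nitrogen would also stay within the scatter remains open.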